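The source may report more compounds than this note shows. Statements on the series, on what has been measured and on what is new or still open speak of the compounds shown alone.

The study concerns a small set of pyrimidinedione compounds tested in a functional assay on HeLa cells (Homo sapiens) for inhibition, read by MTT assay, with a stated time of 72 h; a lower number here means a stronger inhibitor, a higher number a weaker inhibitor. Within the data shown here, compound 1, with the structure `N[C@H](CSCC(=O)Nc1c[nH]c(=O)[nH]c1=O)C(=O)O`, is the only member with a definite number: in this assay compound 1 gives 86000 nM. Compound 2, with the structure `Cc1cc(=O)[nH]c(=O)n1COC(CO)CO`, has no number of its own. In this assay compound 2 gives > 100000 nM, which is a limit of the assay and not a measured value. Going by these compounds, compound 2 therefore stands at the limit of > 100000 nM in this assay, at which 1 of the 2 values shown sits, so its true potency is unknown beyond the fact that it was not resolved.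

Compound 3, with the structure `O=c1ccn(COC(CO)CO)c(=O)[nH]1`, has not yet been measured in this assay. It differs from compound 2 by hydrogen in place of methyl on an aromatic carbon. Among the measured compounds shown here, no measured pair in this set shares that change, so nothing here shows how large an effect it has. Given that compound 2 reached only the limit > 100000 nM, compound 3 is expected to remain near that limit, with a step that the limit leaves unreadable from compound 2 to compound 3 that may not be visible at all. The estimate for compound 3 is 150000 nM, within a range from 60000 nM to 400000 nM, and a limit rather than a number is the more likely outcome.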

Compound 3, half-maximal inhibitory concentration: > 100000 nM
Compound 3: a limit, no number; the forecaster's own chance of this, stated with the estimate: 75%; the middle value is on the limit's open side.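

In this assay compound 3 gives > 100000 nM, which is a limit of the assay and not a number. Among these compounds, compound 2 also stands at a limit, so no step from compound 2 to compound 3 can be read: the limit of > 100000 nM in this assay, at which 2 of the 3 values shown sit. The compounds shown leave open whether hydrogen in place of methyl on an aromatic carbon changes potency at all.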